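The source may report more compounds than this note shows. Statements on the series, on what has been measured and on what is new or still open speak of the compounds shown alone.

Measured compounds:
compound 1 `C=CCn1c(N)c(C#N)c2c(N)ncnc21`: > 100000 nM
compound 2 `COc1ccc(Cn2c(N)c(C#N)c3c(N)ncnc32)cc1`: 50000 nM

In a functional assay on KB cells (Homo sapiens) for inhibition (a higher number here means a weaker inhibitor, a lower number a stronger inhibitor), compound 1 gives > 100000 nM, which is a limit of the assay and not a number. On the numbers shown, compound 1 thus stands only at the limit of > 100000 nM in this assay, at which 1 of the 2 values shown sits. In this assay compound 2 gives 50000 nM. For the measured compounds named here, no step between compound 1 and compound 2 is computed, so their two values can only be set side by side. Compound 3 `COCCOCn1c(N)c(C#N)c2c(N)ncnc21` is not yet measured. It differs from compound 1 in one place: 2-methoxyethoxy in place of vinyl on a saturated chain carbon bound to an aromatic nitrogen. None of the measured compounds carries this change, so no cause can be given for its effect. One expects no step beyond the scatter in this assay. The estimated step of a number no higher from compound 1 to compound 3 (the limit leaves the size open) is expected to leave compound 3 close to where compound 1 sits. For compound 3 one expects 100000 nM in this assay, with a range from 30000 nM to 300000 nM, and a real chance that only a limit is reported again.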

Compound 3, half-maximal inhibitory concentration: 210000 nM
For compound 3 the middle estimate is 2.1-fold (0.32 log units) below the measured one, and the stated range covers the measured number.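

In this assay, for the compounds shown here, compound 1 gives > 100000 nM, which is a limit of the assay and not a number, and no step to compound 3 can be read from it. The compounds shown leave open what 2-methoxyethoxy in place of vinyl does to the value in this assay.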